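Removing a Pyrazole Methyl from a Weak MCF7 Cytotoxic Sulfonamide

The compounds below may be only part of what the source reports. "The series", "measured", "known", "first", "only" and "open" are said of these compounds alone.

Compound 1 `Cc1cc(-c2ccccc2)n(/C(N)=N/S(=O)(=O)c2cc(C)c(Cl)cc2SCc2cccc3ccccc23)n1` was tested in a functional assay on MCF7 cells (Homo sapiens) for cytotoxicity, read by MTT assay, with a stated time of 72 h (on this read-out higher numbers stand for weaker inhibition and lower numbers for stronger inhibition), and gave 170000 nM. Going by the values given here, of the two compounds measured, this is the highest number; the only neighbour is compound 2 `Cc1cc(-c2ccccc2)n(/C(N)=N/S(=O)(=O)c2cc(C)c(Cl)cc2SCc2ccccc2C)n1`, which in this assay gives 80000 nM, the step being a 2.1-fold lower number from compound 1 to compound 2 (0.33 log units; beyond the scatter).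

Compound 3 `Cc1cc(S(=O)(=O)/N=C(\N)n2nccc2-c2ccccc2)c(SCc2cccc3ccccc23)cc1Cl` is not yet measured. Relative to compound 1 the change is hydrogen in place of methyl on an aromatic carbon, which cut one bond further out reads 3-methyl-5-phenyl-1H-pyrazol-1-yl to 5-phenyl-1H-pyrazol-1-yl. Among the compounds with values here, no measured step touches this part of the molecule: the one available step concerns the group on the sulfur-bound chain carbon, not the five-membered ring. There is therefore no basis for expecting a change beyond the scatter in either direction.

Compound 3 is expected to give about 170000 nM in this assay, within 70000 nM to 400000 nM, an expected step of no change at the digits printed from compound 1 to compound 3 (within the scatter).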

Compound 3, half-maximal inhibitory concentration: 58000 nM
Compound 3: middle estimate off by 2.9-fold (0.47 log units), on the high side; the whole stated range lies above it.
By their numbers in this assay, from the lowest: compounds 3 and 2 (each within the scatter of the next); then compound 1.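

In this assay, the step of a 2.9-fold lower number from compound 1 to compound 3 (0.47 log units; beyond the scatter) shows that this carbon of the five-membered ring is not a silent position: swapping one methyl for hydrogen is enough to move the number beyond the scatter. Going by these compounds alone, the earlier step concerned only the group on the sulfur-bound chain carbon, so this is the first sign that the ring bearing the phenyl group also bears on the read-out, with the hydrogen giving the lower number in this pair. No measurement here gives a reason for this shift.

As far as these compounds go, it remains open how other groups at this carbon would read, such as an ethyl, a trifluoromethyl or an amine. Also open, from the compounds shown here alone, is whether the same swap would give a similar step with the 2-methylphenyl group of compound 2 in place of the naphthalen-1-yl group.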